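The source may hold more compounds than are shown below. What is called first, only, known or untested is meant among the compounds shown, and "the series" means these compounds.

Cytotoxicity notes on the amine series built on the shared core. Compound 1 `CCCc1ccsc1CN[C@@H]1C[C@H]2C[C@@H]([C@H]1C)C2(C)C` gives, in an ADME assay on MDCK cells (Canis lupus familiaris) for cytotoxicity, read by microscopy, with a stated time of 48 h (on this read-out higher numbers stand for lower toxicity in this test and lower numbers for higher toxicity in this test), a value of 50000 nM, the highest of the two numbers recorded so far. Within the data shown here, compound 2 `CCc1ccc(CN[C@@H]2C[C@H]3C[C@@H]([C@H]2C)C3(C)C)s1` gives in this assay 1560 nM, a lower number than compound 1, and the two values differ by more than the usual scatter; no single-point step between the two is available, so only the two readings themselves are on hand.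

Compound 3 `C[C@H]1[C@H](NCc2sccc2-c2ccccc2)C[C@H]2C[C@@H]1C2(C)C` has not yet been measured. It differs from compound 1 by phenyl in place of propyl on an aromatic carbon.

Among the measured compounds shown here, no measured step tells how this change behaves in this assay. A downward step of moderate size is expected, a 4.2-fold lower number from compound 1 to compound 3 (0.62 log units; beyond the scatter), and compound 3 is therefore estimated at 12000 nM, within a range from 2500 nM to 50000 nM.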

Compound 3, minimum cytotoxic concentration: 12500 nM
Beside the measured number, compound 3's estimate is 1.0-fold (0.02 log units) below it; the range from low to high includes it.
By their numbers in this assay, from the lowest: compound 2; then compound 3; then compound 1.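

Among these compounds, at the aromatic carbon two ring bonds from the ring sulfur, phenyl in place of propyl gives the first single-place step in this assay: a 4.0-fold lower number from compound 1 to compound 3 (0.60 log units; beyond the scatter) is what the change does. Among the compounds shown here, the read-out at this position therefore responds to the group it carries, with phenyl reading as the more toxic in this test of the two groups compared here, although only one such pair exists. Nothing on hand explains the step.

Going by these compounds, it remains open whether the step follows the aromatic ring itself or only the larger count of carbons, a question that a cyclohexyl group or a longer chain at the same carbon would address. Also open, on these data alone, is how a pyridyl ring, or an amine or a carboxylic acid on the phenyl, would read at this place.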